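The source may hold more compounds than are shown below. What is called first, only, known or untested is meant among the compounds shown, and "the series" means these compounds.

Compound 1 `COc1nc2ccc(Br)cc2cc1C(c1ccccc1)n1cc(-c2cccc(F)c2)nn1` gives 12.7% in an ADME assay on SK-OV-3 cells (Homo sapiens) for cytotoxicity, read by sulforhodamine B assay, with a stated time of 48 h, tested at 10 uM; a higher number here means more inhibition at the concentration tested (going by the name of the read-out), a lower number less inhibition.
Compound 2 `COc1nc2ccc(Br)cc2cc1C(c1ccccc1)n1cc(CCCO)nn1` gives 13.8% in this assay.
Compound 3 `COc1nc2ccc(Br)cc2cc1C(c1ccccc1)n1cc(-c2ccc(F)cc2)nn1` gives 14.3% in this assay.

Compound 3 has the highest of the three numbers in this assay, but its gaps to compound 2 and to compound 1 both lie within the scatter, so the three compounds cannot be told apart. Compound 4 `CCOC(=O)c1cn(C(c2ccccc2)c2cc3cc(Br)ccc3nc2OC)nn1` differs from compound 3 by ethoxycarbonyl in place of 4-fluorophenyl on an aromatic carbon. For the measured compounds named here, no measured step involves an ethoxycarbonyl group; the steps that bear on the same aromatic carbon are a number 1.1 percentage points higher from compound 1 to compound 2 (within the scatter), a number 1.6 percentage points higher from compound 1 to compound 3 (within the scatter) and a number 0.5 percentage points higher from compound 2 to compound 3 (within the scatter), and each stayed within the scatter. On this basis, compound 4 is expected to show no step beyond the scatter, a number 1.3 percentage points lower from compound 3 to compound 4 (within the scatter). Compound 4 is therefore estimated at 13%, with a range from 4% to 24%.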

Compound 4, a percentage reported as inhibition, at one concentration (the size of the read-out at that concentration, not a potency): 2.01%
Compound 4: the middle estimate sits 11 percentage points above what was measured; the measured number lies below the stated range.
By their numbers in this assay, from the lowest: compound 4; then compounds 1, 2 and 3 (each within the scatter of the next).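

In this assay, ethoxycarbonyl on this aromatic carbon of the five-membered ring gives a number 12.3 percentage points lower from compound 3 to compound 4 (beyond the scatter), a number 11.8 percentage points lower from compound 2 to compound 4 (beyond the scatter) and a number 10.7 percentage points lower from compound 1 to compound 4 (beyond the scatter). The position is therefore not indifferent to what it carries: 3-fluorophenyl, 4-fluorophenyl and 3-hydroxypropyl could not be told apart, while ethoxycarbonyl stands apart from all three. Nothing available explains this difference. On these data alone, what a carboxylic acid or an amide on this carbon would give remains open, and so does whether the lower number follows the carbonyl or the ethyl part of ethoxycarbonyl.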